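Chain extension on the amide side of compound 1

The source may report more compounds than this note shows. Statements on the series, on what has been measured and on what is new or still open speak of the compounds shown alone.

Compound 1 `CCCCCCCCCCCCNC(=O)[C@@H](NC(=O)c1ccccc1)[C@@H](C)O` gives 200000 nM in a functional assay on SW-620 cells (Homo sapiens) for cytotoxicity, read by MTT assay, with a stated time of 48 h (on this read-out higher numbers stand for weaker inhibition and lower numbers for stronger inhibition), the higher of the two numbers in hand. Compound 2 `CCCCCCCCCCCCNC(=O)[C@@H](NC(=O)c1cccs1)[C@@H](C)O` gives 29200 nM in this assay; the step of a 6.8-fold lower number from compound 1 to compound 2 (0.84 log units; beyond the scatter) is the only measured one in the set and concerns the aryl amide, not the chain. Going by the values given here, compound 3 `CCCCCCCCCCCCCCCCCCNC(=O)[C@@H](NC(=O)c1ccccc1)[C@@H](C)O` differs from compound 1 by hexyl in place of hydrogen on a saturated chain carbon, ten or more bonds along the chain from an amide-type nitrogen, a change to which no measured step applies; the two measured compounds share the same chain. The expectation for compound 3 therefore rests on compound 1 alone, and with nothing pointing either way the expected step of a 1.3-fold lower number from compound 1 to compound 3 (0.12 log units; within the scatter) is none beyond the scatter, with a wide range to reflect that. Compound 3 is expected to give about 150000 nM in this assay, estimated to lie between 30000 nM and 500000 nM.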

Compound 3, half-maximal inhibitory concentration: 200000 nM
Compound 3: the middle estimate sits 1.3-fold (0.12 log units) below what was measured, and the stated range covers the measured number.
By their numbers in this assay, from the lowest: compound 2; then compounds 1 and 3 (each within the scatter of the next).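

Hexyl in place of hydrogen at this place on the chain shows no change at the digits printed from compound 1 to compound 3 (within the scatter) in this assay, so on the phenyl amide the added carbons do not move the number beyond the scatter. The aryl amide remains the only place in the series with a step beyond the scatter, a 6.8-fold lower number from compound 1 to compound 2 (0.84 log units; beyond the scatter) in this assay, while this chain change has none. Nothing measured here explains why the number stays in place.

Going by these compounds, whether the thiophen-2-yl amide keeps its lower number when carried on the longer chain of compound 3 stays open. Also open, on these data alone, is how a shorter chain, or an amine or a carboxylic acid in place of the hexyl, would read in this assay on this core.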